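The compounds below may be only part of what the source reports. "The series", "measured", "known", "first", "only" and "open" are said of these compounds alone.

Compound 1 `CC/N=C(\S)NCCCCCCn1nc(-c2ccccc2)ccc1=O` is the starting point of this account. In a functional assay on the whole organism with Rattus norvegicus as the target, at a dose of 100 mg/kg (a lower number here means less inhibition, a higher number more inhibition at the dose given (going by the name of the read-out)), compound 1 gives -5.6%, the lowest of the three numbers measured; its nearest neighbour is compound 2, and its furthest is compound 3. Compound 2 `CCC/N=C(/NC#N)NCCCCCn1nc(-c2ccccc2)ccc1=O` gives 27.5% in this assay, and compound 3 `CC/N=C(/NC#N)NCCCCCCn1nc(-c2ccccc2)ccc1=O` gives 29.1%. Both of these are reached from compound 1 by a single change: a number 33.1 percentage points higher from compound 1 to compound 2 (beyond the scatter), and a number 34.7 percentage points higher from compound 1 to compound 3 (beyond the scatter). Between the two cyanoguanidines the carbons are merely moved about, and that step was small: a number 1.6 percentage points higher from compound 2 to compound 3 (within the scatter).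

Compound 4 `CC(C)C/N=C(\S)NCCCCn1nc(-c2ccccc2)ccc1=O` keeps the thiourea of compound 1 and the same atoms, joined differently: a group of 8 heavy atoms (5 carbon, 2 nitrogen, 1 sulfur; no ring) in place of a group of 8 heavy atoms (5 carbon, 2 nitrogen, 1 sulfur; no ring), on a saturated chain carbon, four bonds along the chain from an aromatic nitrogen. Among the measured compounds shown here, no measured step changes a thiourea in this way. For the measured compounds named here, the only step that resembles it is the redistribution of carbons from compound 2 to compound 3, which stayed within the scatter, whereas the two large steps from compound 1 came from a change of group that compound 4 does not make. He therefore expects no step beyond the scatter, a number 5.6 percentage points higher from compound 1 to compound 4 (within the scatter), and estimates compound 4 at 0%, in a range from -15% to 15%.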

Compound 4, a percentage reported as inhibition, in the whole organism at one dose (the size of the read-out at that dose, not a potency): 35.8%
Compound 4: middle estimate off by 35.8 percentage points, on the low side, and the stated range ends below it.
By their numbers in this assay, from the lowest: compound 1; then compounds 2, 3 and 4 (each within the scatter of the next).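

The step of a number 41.4 percentage points higher from compound 1 to compound 4 (beyond the scatter) shows that in this assay a large rise at this position does not require leaving the thiourea: the group that enters has the same atoms and the same counted features as the group that leaves, and only the way those atoms are joined differs. The earlier large steps, a number 33.1 percentage points higher from compound 1 to compound 2 (beyond the scatter) and a number 34.7 percentage points higher from compound 1 to compound 3 (beyond the scatter), both replaced the thiourea, so on their own they could not show that the low number of compound 1 is not a fixed feature of every thiourea in this set, whereas compound 4 shows exactly that. Nothing measured here explains why rearranging the same atoms on a saturated chain carbon, four bonds along the chain from an aromatic nitrogen, has so large an effect.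

The compounds shown do not separate the length of the chain from the branching at the far end of the group, since both differ in the single step from one thiourea to the other. Going by these compounds, how a urea in place of the thiourea, or a longer chain carrying the same branched end, would behave in this assay remains open.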